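Cyano replacement in compound 2: working notes

The source may hold more compounds than are shown below. What is called first, only, known or untested is meant among the compounds shown, and "the series" means these compounds.

- Compound 1 `N#Cc1cccc(-c2cc(F)c3ncc(Cc4ccc5ncccc5c4)n3c2)c1`: 107 nM
- Compound 2 `N#Cc1ccc(-c2cc(F)c3ncc(Cc4ccc5ncccc5c4)n3c2)cc1F`: 145 nM

In a functional assay on EBC-1 cells (Homo sapiens) for antiproliferative activity, with a stated time of 72 h (on this read-out higher numbers stand for weaker inhibition and lower numbers for stronger inhibition), compound 2 gives 145 nM, within the scatter of compound 1. Compound 3 `O=C(NCCCN1CCCC1)c1ccc(-c2cc(F)c3ncc(Cc4ccc5ncccc5c4)n3c2)cc1F` differs from compound 2 as follows: (3-(pyrrolidin-1-yl)propyl)carbamoyl in place of cyano on an aromatic carbon. The group enters on an aromatic carbon, ortho to a fluoro group and para to a large group. Going by the values given here, the only measured step, a 1.4-fold higher number from compound 1 to compound 2 (0.13 log units; within the scatter), lies within the scatter, and it does not replace the cyano group. The data therefore give no direction, and the range stays wide. The expected change is small: a 1.2-fold lower number from compound 2 to compound 3 (0.08 log units; within the scatter). For compound 3 the estimated value is 120 nM, with an expected range of 35 nM to 450 nM.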

Compound 3, half-maximal inhibitory concentration: 161 nM
Estimate against measurement, compound 3: 1.3-fold (0.13 log units) below, and the stated range covers the measured number.
By their numbers in this assay, from the lowest: compounds 1, 2 and 3 (each within the scatter of the next).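

The step of a 1.1-fold higher number from compound 2 to compound 3 (0.05 log units; within the scatter) in this assay lies within the scatter. This place on the aromatic carbon, ortho to a fluoro group and para to a large group, therefore accepts (3-(pyrrolidin-1-yl)propyl)carbamoyl, with 11 heavy atoms and a ring, in place of the 2 heavy atoms of cyano with no change beyond the scatter. No supporting measurement bears on the reason for this result.

Going by these compounds, a carboxylic acid or a primary amide at this carbon remains open. So do a shorter chain and a morpholine in place of the pyrrolidine.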